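The source may report more compounds than this note shows. Statements on the series, on what has been measured and on what is new or still open speak of the compounds shown alone.

Compound 1 `NC(=O)[C@@H](NCc1ccc(OCc2cccc(Cl)c2)cc1)c1ccccc1` and compound 2 `NC(=O)[C@H](CO)NCc1ccc(OCc2cccc(Cl)c2)cc1` are two amides built on the same core, and both were tested in an assay on mitochondria for inhibition of Amine oxidase [flavin-containing] B (Rattus norvegicus); on this read-out higher numbers stand for weaker inhibition and lower numbers for stronger inhibition. In this assay compound 1 gives 10100 nM, while compound 2 gives 43 nM, which amounts to a 230-fold lower number from compound 1 to compound 2 (2.37 log units; beyond the scatter). Going by the values given here, of the two numbers measured so far, compound 2 therefore stands at the lowest, the nearest neighbour being compound 1 with its far higher number. Compound 3 `NC(=O)[C@H](CO)NCc1ccc(OCc2ccccc2)cc1` differs from compound 2 in one place only: hydrogen in place of chloro on an aromatic carbon. Among the compounds with values here, the single measured step concerned the group on the saturated chain carbon, not the chloro on the aromatic ring, so it offers no direct guide to this change. With nothing to set against it, compound 3 is expected to land close to compound 2, with a modest drift toward a higher number as the likelier direction, that is a 1.9-fold higher number from compound 2 to compound 3 (0.27 log units; within the scatter). The estimate for compound 3 is accordingly 80 nM, within a range from 30 nM to 250 nM.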

Compound 3, half-maximal inhibitory concentration: 410 nM
Compound 3: middle estimate off by 5.1-fold (0.71 log units), on the low side; measured number outside the range, above it.
By their numbers in this assay, from the lowest: compound 2; then compound 3; then compound 1.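

Taking away the chloro, so that 3-chlorophenyl becomes phenyl, gives a 9.5-fold higher number from compound 2 to compound 3 (0.98 log units; beyond the scatter) in this assay. Going by these compounds alone, the earlier step, a 230-fold lower number from compound 1 to compound 2 (2.37 log units; beyond the scatter), showed only that the group on the saturated chain carbon matters; this one shows that the far end of the molecule counts too, and that a single heavy atom on an aromatic carbon is enough to move the number beyond the usual scatter. The compounds shown offer no measurement that would explain this effect of the chloro.

Still open, as far as these compounds go, is whether a fluoro, a bromo or a methoxy group on that aromatic carbon would do what the chloro does, or whether only the chloro gives the lower number. Also open, from the compounds shown here alone, is whether removing the chloro would matter as much with phenyl in place of hydroxymethyl on the chain carbon, as in compound 1.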